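Vinyl in place of methyl on compound 1

The source may hold more compounds than are shown below. What is called first, only, known or untested is meant among the compounds shown, and "the series" means these compounds.

Compound 1 `Cc1cccc(C(=O)N2CCCC(C(=O)Nc3ccc(Cl)cc3)C2)c1` is the starting point for the step considered here. In an ADME assay on PC-3 cells (Homo sapiens) for cytotoxicity, read by WST assay, tested at 100 uM (on this read-out higher numbers stand for more inhibition at the one concentration tested (going by the name of the read-out) and lower numbers for less inhibition), compound 1 gives 0%. Two further compounds carry the same core with a different acyl group and a different substituent on the aniline ring: compound 2 `CC(C)(C)OC(=O)c1cccc(NC(=O)C2CCCN(C(=O)c3cc(C(F)(F)F)cc(C(F)(F)F)c3)C2)c1` gives 0% in this assay, and compound 3 `COC(=O)c1cccc(NC(=O)C2CCCN(C(=O)c3cc(C(F)(F)F)cc(C(F)(F)F)c3)C2)c1` gives 0%. Compound 1 therefore stands level with compound 2 and compound 3, all three within the scatter of one another at the bottom of the scale.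

Among the measured compounds shown here, the single measured step, no change at the digits printed from compound 2 to compound 3 (within the scatter), concerns the ester alkyl group and leaves the read-out flat. Compound 4 `C=Cc1cccc(C(=O)N2CCCC(C(=O)Nc3ccc(Cl)cc3)C2)c1` differs from compound 1 by vinyl in place of methyl on an aromatic carbon. For the measured compounds named here, no measured step touches that aromatic position, so the step from compound 1 to compound 4 cannot be calibrated directly; the only guidance is that every measured compound shows no inhibition in this assay and that the one measured step is flat.

The expected step of no change at the digits printed from compound 1 to compound 4 (within the scatter) is accordingly within the scatter. Compound 4 is estimated at 0% in this assay, with a range from -10% to 10%.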

Compound 4, a percentage reported as inhibition, at one concentration (the size of the read-out at that concentration, not a potency): 0%
The estimate for compound 4 equals the measured number at the digits printed, and the stated range covers the measured number.
By their numbers in this assay, from the lowest: compounds 1, 2, 3 and 4 (each within the scatter of the next).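

In this assay, among the compounds shown here, the change from 3-methylphenyl to 3-vinylphenyl reads as no change at the digits printed from compound 1 to compound 4 (within the scatter), the first measured step at this aromatic carbon, as the earlier step touched only the ester alkyl group. Compound 1 already gives 0%, so the step shows that vinyl, with its extra carbon and its double bond outside aromatic rings, brings no inhibition into view at this position at the one concentration tested, but it cannot show whether anything was lost. No evidence is available that bears on this result.

It remains open whether a primary amine, a carboxylic acid or a longer chain such as propyl in place of methyl on this aromatic carbon would move the read-out in this assay away from the level shared by the compounds shown. As far as these compounds go, it also remains open whether vinyl in place of methyl would stay as flat on an acyl group carrying two trifluoromethyl groups, as in compound 2 and compound 3.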